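Trimming the Ester Chain of a Kinase Inhibitor

The source may hold more compounds than are shown below. What is called first, only, known or untested is meant among the compounds shown, and "the series" means these compounds.

Compound 1 `NCc1ccc(C(=O)Nc2ccncc2)cc1-c1cccc(C(=O)OCC2CCCCC2)c1` is the weakest of the three compounds measured here. In an assay on isolated protein for inhibition of Rho-associated protein kinase 2 (Homo sapiens), read by radiometric assay (a higher number here means a weaker inhibitor, a lower number a stronger inhibitor), compound 1 gives 48 nM. Compound 2 `NCc1ccc(C(=O)Nc2ccncc2F)cc1-c1cccc(C(=O)OCCO)c1` gives 1.4 nM, and compound 3 `CC(N)c1ccc(C(=O)Nc2ccncc2)cc1-c1ccc(F)cc1` gives 1.2 nM; both differ from compound 1 in more than one place, so only their values can be set side by side. Compound 4 `CCOC(=O)c1cccc(-c2cc(C(=O)Nc3ccncc3)ccc2CN)c1` carries a single change from compound 1: methyl in place of cyclohexyl on a saturated chain carbon bound to an oxygen next to a carbonyl group, so the cyclohexylmethyl ester becomes an ethyl ester. Going by the values given here, no measured pair isolates this change. Because compound 2 with a smaller ester group gives 1.4 nM, a move toward a lower number is expected. The expected step is a 2.4-fold lower number from compound 1 to compound 4 (0.38 log units; beyond the scatter), likely not far beyond the usual scatter. Compound 4 is estimated at 20 nM, between 6 nM and 70 nM.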

Compound 4, half-maximal inhibitory concentration: < 1 nM
Compound 4 gave a limit, no number; the forecaster's own chance of this, stated with the estimate: 2%; at least 20-fold (1.30 log units) between middle value and limit.
By their numbers in this assay, from the lowest: compounds 3 and 2 (each within the scatter of the next); then compound 1. At a limit, below all of these: compound 4.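

Putting methyl in place of cyclohexyl on this saturated chain carbon gives an at least 48-fold lower number from compound 1 to compound 4 (1.68 log units; beyond the scatter), the first single-change step measured at this position. It shows that the group at the end of the ester chain strongly affects the reading and that the cyclohexyl ring is not needed for a low number. The value of compound 4 is a limit of the assay, not a number: the limit of < 1 nM in this assay, at which 1 of the 4 values shown sits.

The compounds shown leave open how the number responds to a methyl ester or a propyl ester at this position. They also leave open what happens when a carboxylic acid or an amide replaces the ester.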